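This account rests on a few compounds, and the source may have more. Where it says the series, first, only, none or still open, it means among the compounds named here.

Three compounds in this set share one core, in which a six-membered aromatic ring of carbon only carries an imidazoline-bearing ether side chain and, on an aromatic carbon ortho to that group of 7 heavy atoms, a second aromatic ring. Compound 1 `Cc1cccnc1-c1ccccc1OCC1=NCCN1` carries a methylated pyridine there. In a functional assay for activation of Alpha-1B adrenergic receptor (Homo sapiens), read by calcium flux (on this read-out higher numbers stand for an effect only at larger amounts of compound and lower numbers for an effect already at smaller amounts), compound 1 gives < 100000 nM, which is a limit of the assay and not a number. Compound 2 `Cc1cccc(-c2ccccc2OCC2=NCCN2)n1` carries the methylated pyridine in another arrangement. In this assay compound 2 gives < 100000 nM, again a limit. Compound 3 `c1ccc(-c2cnccn2)c(OCC2=NCCN2)c1` carries a pyrazine instead. In this assay, going by the values given here, compound 3 gives 631 nM, the only numerical value in the set, since the two other results sit at the limit of < 100000 nM in this assay, at which 2 of the 3 values shown sit.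

Compound 4 `c1c[nH]c(-c2ccccc2OCC2=NCCN2)c1` is not yet measured. It differs from compound 3 in one place: 1H-pyrrol-2-yl in place of pyrazin-2-yl on an aromatic carbon. Among the compounds with values here, no measured pair in this set shows the size of such a change, so any expectation rests on compound 3 alone. The step is expected to stay within the scatter, a 1.3-fold higher number from compound 3 to compound 4 (0.10 log units; within the scatter), with a wide range. Compound 4 is thus estimated to give 800 nM in this assay, between 150 nM and 5000 nM.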

Compound 4, half-maximal effective concentration: 1 nM
For compound 4 the middle estimate is 800-fold (2.90 log units) above the measured one, and the stated range ends above it.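

The aromatic carbon ortho to the group of 7 heavy atoms proves highly sensitive to which ring it carries: in this assay, the change to 1H-pyrrol-2-yl gives a 630-fold lower number from compound 3 to compound 4 (2.80 log units; beyond the scatter). The earlier compounds shown here showed that results differ among the rings at this place, but they offered no measured size for any change there, and this pair now supplies one. Compound 1 and compound 2 still give no readable step to compound 3 or compound 4, as their results are limits of the assay and not numbers: the limit of < 100000 nM in this assay, at which 2 of the 4 values shown sit.

The change from pyrazin-2-yl to 1H-pyrrol-2-yl alters ring size, the count of hetero atoms and the hydrogen-bond donors and acceptors all at once, so the compounds shown cannot say which of these differences goes with the step, and a furan ring or a pyrrole with a methyl group on its nitrogen would be needed to separate them. On these data alone, it also remains open whether the same step would appear with a different link to the imidazoline, such as a longer chain in place of the ether side chain.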